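Amide variation on a shared core: limits only so far

The compounds below may be only part of what the source reports. "The series", "measured", "known", "first", "only" and "open" are said of these compounds alone.

Measured compounds:
- compound 1 `O=C(/C=C/c1coc2cc(O)ccc2c1=O)NCc1ccc(F)cc1`: > 200000 nM
- compound 2 `COc1ccc2c(=O)c(/C=C/C(=O)Nc3cc(C)ccc3C)coc2c1`: > 200000 nM
- compound 3 `Cc1ccc(CNC(=O)/C=C/c2coc3cc(O)ccc3c2=O)cc1`: > 200000 nM

In a functional assay on L02 cells (Homo sapiens) for inhibition, read by MTT assay, with a stated time of 48 h (a lower number here means a stronger inhibitor, a higher number a weaker inhibitor), compound 1 reaches only a limit, > 200000 nM. Compound 3 likewise reaches only a limit, > 200000 nM. The step from compound 1 to compound 3, methyl in place of fluoro on an aromatic carbon, is a step that the two limits leave unreadable from compound 1 to compound 3. Compound 2 also stands at a limit in this assay, > 200000 nM. Among the compounds with values here, every value in this assay so far sits at the limit of > 200000 nM in this assay, at which 3 of the 3 values shown sit; no compound has a number.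

Compound 4 `COc1ccc2c(=O)c(/C=C/C(=O)NCc3ccccc3)coc2c1` is next. It differs from compound 2 by benzyl in place of 2,5-dimethylphenyl on an amide-type nitrogen. Within the data shown here, no measured step touches the amide nitrogen, and the single measured step cannot be read, so nothing points to a change in either direction. Compound 2 at its limit is the reference, and compound 4 is expected to stay at that limit too. The estimate for compound 4 is 250000 nM, with a range from 100000 nM to 600000 nM. The expected step from compound 2 to compound 4 is a step that the limit leaves unreadable from compound 2 to compound 4, none beyond the scatter.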

Compound 4, half-maximal inhibitory concentration: > 200000 nM
Compound 4 was reported as a limit; the forecaster's own chance of this, stated with the estimate: 85%; the middle value lies beyond the limit too.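

Compound 2 and compound 4 each stand only at a limit, not a number, so the step between them cannot be read. The compounds shown leave open whether any amide group on the shared core gives a measurable value in this assay.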